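Amide-nitrogen heteroaryl swap: pyridine to pyrazine

This account rests on a few compounds, and the source may have more. Where it says the series, first, only, none or still open, it means among the compounds named here.

Two members of the series have numbers in a functional assay on the whole organism for inhibition, with Rattus norvegicus as the target, read by cytopathic effect and paw edema, at a dose of 100 mg/kg by the oral route; on this read-out higher numbers stand for more inhibition at the one dose given (going by the name of the read-out) and lower numbers for less inhibition. Compound 1 `COc1ccc(NC(=O)c2c(O)c3cccnc3n(-c3ccccc3)c2=O)cc1` gives -1.9% in this assay, and compound 2 `O=C(Nc1ccncc1)c1c(O)c2cccnc2n(-c2ccccc2)c1=O` gives 24.3%. Going by the values given here, the one measured step, a number 26.2 percentage points higher from compound 1 to compound 2 (beyond the scatter), exchanges an aryl group on the amide-type nitrogen for a nitrogen-containing aromatic ring. On the numbers shown compound 2 stands highest of the two, with compound 1 the nearest and beyond the scatter below it.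

Compound 3 `O=C(Nc1cnccn1)c1c(O)c2cccnc2n(-c2ccccc2)c1=O` is not yet measured. It differs from compound 2 by pyrazin-2-yl in place of pyridin-4-yl on an amide-type nitrogen, so the change sits at the same place as the measured step. That step bears on it only loosely: it compared a 4-methoxyphenyl with a pyridin-4-yl, whereas here one six-membered heteroaromatic ring replaces another. Among the compounds with values here, no measured pair shows what a second ring nitrogen does at this position. The expected step of a number 4.3 percentage points lower from compound 2 to compound 3 (within the scatter) is therefore small, in either direction, and may well stay within the scatter. Compound 3 is estimated at 20% in this assay, with a range from 3% to 37%.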

Compound 3, a percentage reported as inhibition, in the whole organism at one dose (the size of the read-out at that dose, not a potency): 21.2%
Estimate against measurement, compound 3: 1.2 percentage points below; measured number inside the range.
By their numbers in this assay, from the lowest: compound 1; then compounds 3 and 2 (each within the scatter of the next).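

In this assay, the step of a number 3.1 percentage points lower from compound 2 to compound 3 (within the scatter) shows that on the amide-type nitrogen, pyrazin-2-yl, a six-membered aromatic ring with 2 hetero atoms, can take the place of pyridin-4-yl without a change beyond the scatter. The step of a number 23.1 percentage points higher from compound 1 to compound 3 (beyond the scatter) shows that the rise seen on leaving 4-methoxyphenyl is not confined to pyridin-4-yl; it recurs with a second heteroaromatic ring, and none of the three compounds goes against this pattern. No available evidence accounts for either step.

From the compounds shown here alone, with only these three groups at this position, it remains open whether the difference from compound 1 follows from the ring nitrogens or from the loss of the methoxy group, a question that an unsubstituted phenyl on the amide-type nitrogen would address. Also open, going by these compounds, is whether the numbers in this assay hold with a non-aromatic group such as morpholin-4-yl or with a basic side chain such as 2-(dimethylamino)ethyl at this place, and how they would run at other doses.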